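Adding a Second Decyloxy Chain and E-selectin Binding

This account rests on a few compounds, and the source may have more. Where it says the series, first, only, none or still open, it means among the compounds named here.

Measured compounds:
Compound 1 `CCCCCCCCCCOc1cccc(OCCCCCC(=O)N(Cc2ccc(C(=O)O)cc2)c2cccc(C(=O)O)c2)c1` gives 42% in an assay on isolated protein for binding affinity to E-selectin (Homo sapiens), read by ELISA, tested at 100 uM; on this read-out higher numbers stand for more inhibition at the one concentration tested (going by the name of the read-out) and lower numbers for less inhibition.
Compound 2 `CCCCCCCCCCOc1cc(OCCCCCCCCCC)cc(OCCCCCCON=C(c2ccc(Cl)cc2)c2ccc(Cl)cc2)c1` gives 2% in this assay.
Compound 3 `CCCCCCCCCCOc1cccc(OCCCCCC(=O)N(Cc2ccc(C(=O)O)cc2)c2ccc(C(=O)O)cc2)c1` is reported as "not determined" (no result reported) in this assay, with no number given.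

Compound 1 holds the highest of the two numbers; compound 2, its nearest neighbour, lies well beyond the usual scatter below it. Compound 4 `CCCCCCCCCCOc1cc(OCCCCCCCCCC)cc(OCCCCCC(=O)N(Cc2ccc(C(=O)O)cc2)c2cccc(C(=O)O)c2)c1` differs from compound 1 in one place: decyloxy in place of hydrogen on an aromatic carbon. Among the compounds with values here, no pair of measured compounds isolates this change, so its effect in this assay cannot be read from the data; compound 2 also carries two decyloxy groups, but its linker differs, so it gives no clean guide. A small step, downward or none beyond the scatter, is expected, as a number 6 percentage points lower from compound 1 to compound 4 (within the scatter). Compound 4 is estimated at 36%, within 12% to 60%.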

Compound 4, a percentage reported as inhibition, at one concentration (the size of the read-out at that concentration, not a potency): 43%
Compound 4: middle estimate off by 7 percentage points, on the low side, within the range that was stated.
By their numbers in this assay, from the lowest: compound 2; then compounds 1 and 4 (each within the scatter of the next).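

Decyloxy in place of hydrogen on this aromatic carbon gives a number 1 percentage points higher from compound 1 to compound 4 (within the scatter) in this assay on the core of compound 1. This position therefore accepts a second chain of this length, with compound 4 reading within the scatter of compound 1. No evidence at hand explains this result.

On these data alone, whether a short methoxy group, or a chain ending in an amine or a carboxylic acid, would fare alike at this position stays open. A reading at one concentration also leaves open how the potencies of compound 1 and compound 4 compare.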